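Replacing a ring group with cyanomethyl on a carbonyl carbon

A few compounds are considered here, and "the series" means these few. Any claim that something is new, unique, unknown or untested is made for them only; others in the source may bear on it.

Measured so far in an ADME assay on microsomes from liver (Mus musculus) for metabolic stability; on this read-out higher numbers stand for a longer-lived compound and lower numbers for a shorter-lived compound
- compound 1 (`CC1(C(=O)NCCSc2nonc2/C(=N/O)Nc2ccc(F)c(C(F)F)c2)CCN1`) gives 0.268 h
- compound 2 (`NS(=O)(=O)CC(=O)NCCSc1nonc1/C(=N/O)Nc1ccc(F)c(Br)c1`) gives 1.12 h

Among the compounds with values here, with only two measurements there is little to compare, but compound 1 (0.268 h) has the lower number. Compound 2 (1.12 h) lies above it by a gap beyond the usual scatter of repeated measurements. These two compounds differ in more than one place, so that gap cannot be tied to any single structural change.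

Compound 3 (`N#CCC(=O)NCCSc1nonc1/C(=N/O)Nc1ccc(F)c(C(F)F)c1`) has not yet been measured. It keeps the core of compound 1 and changes one group, on a carbonyl carbon, in this way: a group of 3 heavy atoms (2 carbon, 1 nitrogen; no ring) in place of a group of 5 heavy atoms (4 carbon, 1 nitrogen; one four-membered non-aromatic ring with 1 hetero atom), on a carbonyl carbon. Cyanomethyl, with no ring, therefore takes the place of the group with the four-membered non-aromatic ring.

Within the data shown here, no measured pair shows this change on its own, so any forecast is uncertain. Among the measured compounds shown here, the only guide is the higher number of compound 2 (1.12 h), which also lacks that ring. A modest rise in this assay is expected, not clearly beyond the scatter, and the estimated step is a 1.9-fold higher number from compound 1 to compound 3 (0.27 log units; within the scatter) as a rough expectation. Compound 3 is estimated at 0.5 h (expected range 0.2 h to 1.2 h).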

Compound 3, half-life: 0.278 h
Compound 3: middle estimate off by 1.8-fold (0.25 log units), on the high side, and the stated range covers the measured number.
By their numbers in this assay, from the lowest: compounds 1 and 3 (each within the scatter of the next); then compound 2.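

In this assay, putting cyanomethyl in place of the group with the four-membered non-aromatic ring, on a carbonyl carbon whose other neighbour is an amide-type nitrogen, gives a 1.0-fold higher number from compound 1 to compound 3 (0.02 log units; within the scatter) as the step. In this pair, then, the ring and the hydrogen-bond donor of the leaving group can both be absent with no shift in half-life beyond the usual scatter, so losing that ring does not by itself go with a longer-lived compound here, something the first two compounds could not show. No separate data are available to explain why the two groups give matching read-outs.

From the compounds shown here alone, this is a single pair on one background, so it remains open whether the same swap would behave alike with the rest of the molecule altered. Going by these compounds, it is also open whether a quite different group on this carbonyl carbon, such as a carboxylic acid, a primary amine or a longer alkyl chain, would move the half-life beyond the scatter.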